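Aryl variation at the ring-oxygen-adjacent position of the shared core

The source may report more compounds than this note shows. Statements on the series, on what has been measured and on what is new or still open speak of the compounds shown alone.

Measured so far:
compound 1 `CCC1=C(O)c2c(oc(-c3ccc(OC)cc3)cc2=O)C(CC)(CC)C1=O` gives 0.68 uM
compound 2 `CCC1=C(O)c2c(oc(-c3cccc(OC(F)(F)F)c3)cc2=O)C(CC)(CC)C1=O` gives 9.95 uM
compound 3 `CCC1=C(O)c2c(oc(-c3cccc(F)c3)cc2=O)C(CC)(CC)C1=O` gives 3.09 uM

These are values in a functional assay on KBVIN cells (Homo sapiens) for antiproliferative activity, read by sulforhodamine B assay, with a stated time of 3 days; a lower number here means that less compound is needed, a higher number that more compound is needed for the effect. Compound 3 holds the second highest of the three numbers; it sits a 3.2-fold lower number from compound 2 to compound 3 (0.51 log units; beyond the scatter) and a 4.5-fold higher number from compound 1 to compound 3 (0.66 log units; beyond the scatter), so both its neighbours lie beyond the scatter. Compound 4 `CCC1=C(O)c2c(oc(-c3cc(C)cc(C)c3)cc2=O)C(CC)(CC)C1=O` is not yet measured; (3,5-dimethylphenyl in place of 3-fluorophenyl on an aromatic carbon). For the measured compounds named here, neither measured step bears directly on two methyl groups, since both compare one substituent against another rather than two against one; the steps show only that the aryl group moves this assay over a modest span. A step of modest size, likely upward, is expected from compound 3 to compound 4, of a 1.5-fold higher number from compound 3 to compound 4 (0.16 log units; within the scatter). Compound 4 is estimated at 4.5 uM, with a range from 1.5 uM to 13 uM.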

Compound 4, concentration for half-maximal effect: 0.45 uM
For compound 4 the middle estimate is 10-fold (1.00 log units) above the measured one; the measured number lies below the stated range.
By their numbers in this assay, from the lowest: compounds 4 and 1 (each within the scatter of the next); then compound 3; then compound 2.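

In this assay, replacing fluoro with two methyl groups gives a 6.9-fold lower number from compound 3 to compound 4 (0.84 log units; beyond the scatter), so the substituents on this aryl group, next to the ring oxygen, can bring the number down as well as push it up. Against 4-methoxyphenyl, 3,5-dimethylphenyl gives a 1.5-fold lower number from compound 1 to compound 4 (0.18 log units; within the scatter), so these two aryl groups cannot be ordered. No available evidence accounts for either step.

The compounds shown leave open whether a single methyl group, as in 3-methylphenyl, would be enough. As far as these compounds go, how an aryl group bearing an amine or a carboxylic acid would behave here also remains open.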